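Adding a methyl to a fused-ring indole acid

The source may hold more compounds than are shown below. What is called first, only, known or untested is meant among the compounds shown, and "the series" means these compounds.

Two compounds measured in an assay on HeLa cells for displacement of a labelled ligand from thyroid hormone receptor alpha (Homo sapiens) (a lower number here means a stronger inhibitor, a higher number a weaker inhibitor), share an acidic side chain and a substituted benzyl group on a fused bicyclic core. Compound 1, `Cc1cc2cc(OCC(=O)O)ccc2n1Cc1ccc(O)c(C(C)C)c1`, gives 16.3 nM in this assay. Compound 2, `Cc1cc(OCC(=O)O)cc2ccn(Cc3ccc(O)c(C(C)C)c3)c12`, gives 1.09 nM in this assay, the lowest of the two numbers; its nearest neighbour is compound 1, whose number is higher by a margin beyond the usual scatter. Within the data shown here, compound 1 and compound 2 differ in more than one place, so the values alone show only that compound 2 is the stronger of the pair.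

The next compound, compound 3, `Cc1cc(OCC(=O)O)cc2cc(C)n(Cc3ccc(O)c(C(C)C)c3)c12`, is derived from compound 2 by a single change: methyl in place of hydrogen on an aromatic carbon, on an aromatic carbon of the five-membered ring, next to the ring nitrogen and next to the ring atom that bears a large group. Among the measured compounds shown here, no measured pair isolates this change. The methyl adds one carbon and no polar atom, so a modest step, likely within the scatter, is expected from compound 2 to compound 3, a 1.5-fold higher number from compound 2 to compound 3 (0.17 log units; within the scatter). Compound 3 is therefore estimated at 1.6 nM in this assay, with a range from 0.45 nM to 5.5 nM.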

Compound 3, inhibition constant: 2.05 nM
Compound 3: the middle estimate sits 1.3-fold (0.11 log units) below what was measured; the measured number falls inside the stated range.
By their numbers in this assay, from the lowest: compounds 2 and 3 (each within the scatter of the next); then compound 1.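

In this assay, the aromatic carbon of the five-membered ring, next to the ring nitrogen and next to the ring atom that bears a large group, accepts a methyl in place of hydrogen with a step that stays within the scatter: a 1.9-fold higher number from compound 2 to compound 3 (0.27 log units; within the scatter). The same exchange at another aromatic carbon of the shared core, read from compound 1, gives a step that lies beyond the scatter: an 8.0-fold lower number from compound 1 to compound 3 (0.90 log units; beyond the scatter), so of these two carbons, only the second shows a methyl changing the number measurably, and compound 3, which carries both methyl groups, keeps a number in the range of compound 2. Nothing given here bears on why the two carbons answer so differently to one methyl.

The compounds shown leave open whether this carbon of the five-membered ring would take anything larger or different from methyl, such as an ethyl group, a chlorine atom or a methoxy group, with as small a step. They also leave open whether the two methyl steps would read the same with a group other than the isopropyl on the benzyl ring or with a propionic acid side chain in place of the acetic acid one.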